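This account rests on a few compounds, and the source may have more. Where it says the series, first, only, none or still open, it means among the compounds named here.

In a functional assay on B16 cells (Mus musculus) for inhibition (a higher number here means a weaker inhibitor, a lower number a stronger inhibitor), compound 1 `CC(C)CN(CC(=O)N(CC(C)C)NC(=O)OCc1ccccc1)NC(=O)CBr` gives 3300 nM and compound 2 `CC(C)CN(NC(=O)OCc1ccccc1)C(=O)CN(Cc1ccccc1)NC(=O)CBr` gives 1800 nM, so compound 2 stands level with compound 1 within the scatter. Compound 3 `O=C(CN(Cc1ccccc1)NC(=O)CBr)NNC(=O)OCc1ccccc1` differs from compound 2 in one place: hydrogen in place of isobutyl on an amide-type nitrogen. Going by the values given here, the only measured step, a 1.8-fold lower number from compound 1 to compound 2 (0.26 log units; within the scatter), involves a saturated chain carbon bound to an amine nitrogen, so it offers only weak guidance, and no step beyond the scatter is expected. For compound 3 the estimated value is 2500 nM, with an expected range from 800 nM to 8000 nM. The estimated change is a 1.4-fold higher number from compound 2 to compound 3 (0.14 log units; within the scatter).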

Compound 3, half-maximal inhibitory concentration: 1500 nM
Compound 3: middle estimate off by 1.7-fold (0.22 log units), on the high side; the measured number falls inside the stated range.
By their numbers in this assay, from the lowest: compounds 3, 2 and 1 (each within the scatter of the next, the first and the last beyond it).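

Hydrogen in place of isobutyl on this amide-type nitrogen gives a 1.2-fold lower number from compound 2 to compound 3 (0.08 log units; within the scatter) in this assay. The two compounds therefore stand level, and in this pair inhibition does not depend on the isobutyl group at this position. Nothing available explains why this nitrogen accepts either hydrogen or isobutyl. Still open, from the compounds shown here alone, is whether a longer chain, an amine or a carboxylic acid at this position would move the number beyond the scatter. Also open, going by these compounds, is whether hydrogen would be accepted as well if the rest of the molecule were different.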